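This account rests on a few compounds, and the source may have more. Where it says the series, first, only, none or still open, it means among the compounds named here.

For the measured compounds named here, compound 2 `CCCCNc1nc(N)nc2c1CN(C(=O)c1csc(N)n1)CC2` stands highest of the two numbers so far in an assay on HEK293 cells for agonist activity at Toll-like receptor 8 (Homo sapiens), read by a luciferase reporter, with a stated time of 6 h (a higher number here means that more compound is needed for the effect, a lower number that less compound is needed), where compound 2 gives 6.9 uM. Going by the values given here, the only other measured member, compound 1 `CCCCNc1nc(N)nc2c1CN(Cc1ccco1)CC2`, gives 0.08 uM in this assay, and the step of an 86-fold higher number from compound 1 to compound 2 (1.94 log units; beyond the scatter) is the sole measured step in the set. Compound 3 `CCCCNc1nc(N)nc2c1CN(C(=O)c1cocn1)CC2` has not yet been measured in this assay. The change is 1,3-oxazol-4-yl in place of 2-amino-1,3-thiazol-4-yl on a carbonyl carbon. Among the compounds with values here, the one measured step does not bear directly on this change: it replaced the whole group on the amine nitrogen in the ring, so nothing measured separates the contribution of the ring on the carbonyl carbon from that of the carbonyl itself. Within the data shown here, with no step touching this position, the working expectation is a number near that of compound 2, with wide uncertainty in either direction. For compound 3 the estimate in this assay is 10 uM (range 2 uM to 50 uM), an expected step of a 1.4-fold higher number from compound 2 to compound 3 (0.16 log units; within the scatter).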

Compound 3, minimum effective concentration: 0.2 uM
For compound 3 the middle estimate is 50-fold (1.70 log units) above the measured one; measured number below the stated range.
By their numbers in this assay, from the lowest: compound 1; then compound 3; then compound 2.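

In this assay, the group on the carbonyl carbon proves decisive: 1,3-oxazol-4-yl in place of 2-amino-1,3-thiazol-4-yl gives a 35-fold lower number from compound 2 to compound 3 (1.54 log units; beyond the scatter) with the carbonyl kept, so the carbonyl alone does not set the high number of compound 2. The other new step, a 2.5-fold higher number from compound 1 to compound 3 (0.40 log units; beyond the scatter) and beyond the scatter but modest, shows that a carbonyl-linked ring on this nitrogen can come close to the (furan-2-yl)methyl group of compound 1. Nothing on hand offers an explanation for either step.

The change from compound 2 to compound 3 swaps the ring and removes the amine together, so their shares remain unseparated; a plain 1,3-thiazol-4-yl would divide them. A (1,3-oxazol-4-yl)methyl group would isolate what the carbonyl contributes.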